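The source may hold more compounds than are shown below. What is called first, only, known or untested is meant among the compounds shown, and "the series" means these compounds.

Two compounds carry numbers in an assay on isolated protein for inhibition of lysosomal Pro-X carboxypeptidase (Mus musculus), read by fluorescence, with a stated time of 30 min; a higher number here means a weaker inhibitor, a lower number a stronger inhibitor. Compound 1 `O=C([C@@H]1CC[C@@H](NCc2ccc(Cl)cc2)C[C@H]1c1ccc(F)cc1)N1CC(c2ccccc2)(c2ccccc2)C1` gives 4.7 nM. Compound 2 `Fc1ccc([C@@H]2CN(CCC(F)(F)F)CC[C@H]2c2cc(-c3ccc(Cl)cc3)n[nH]2)cc1` gives 56 nM. Compound 2 stands highest of these two, and its nearest neighbour compound 1 sits at a lower number by a gap beyond the scatter of repeated measurements; the two structures differ in several places at once, so that gap is not tied to any single change.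

Compound 3 `CC(C)(C)CN1CC[C@@H](c2cc(-c3ccc(Cl)cc3)n[nH]2)[C@H](c2ccc(F)cc2)C1` is not yet measured in this assay. It differs from compound 2 in one place: tert-butyl in place of 2,2,2-trifluoroethyl on a saturated chain carbon bound to an amine nitrogen in a ring. Going by the values given here, no pair of measured compounds differs by a single change, so there is no measured step at this position to lean on. The expectation for this step is a change of at most modest size, in no settled direction, most likely within the scatter of repeated measurements of this assay, which is what the expected step of a 1.1-fold higher number from compound 2 to compound 3 (0.03 log units; within the scatter) expresses. On that basis compound 3 is estimated at 60 nM, with an expected range from 20 nM to 180 nM.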

Compound 3, half-maximal inhibitory concentration: 180 nM
Compound 3: middle estimate off by 3.0-fold (0.48 log units), on the low side; measured number inside the range.
By their numbers in this assay, from the lowest: compound 1; then compound 2; then compound 3.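

In this assay, this is the series' first step that differs in one place, and it shows that this position responds to the group it carries: tert-butyl in place of 2,2,2-trifluoroethyl on a saturated chain carbon bound to an amine nitrogen in a ring gives a 3.2-fold higher number from compound 2 to compound 3 (0.51 log units; beyond the scatter). Neither group has a ring, a hydrogen-bond donor or acceptor, or a net charge, so the change is an all-carbon group replacing a fluorine-bearing one, and the modest step still lies beyond the scatter. Nothing measured on these compounds gives a reason for the direction of this step.

From the compounds shown here alone, a single step does not define a trend at this position, so it remains open how an ethyl group, a longer chain, or a chain ending in a hydroxyl group or an amine would read in the same place. Compound 1 differs from compound 2 and compound 3 in several places at once, which leaves open whether this step would carry over to the core of compound 1.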